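Methyl on the Aromatic Nitrogen Across Two Cores

This account rests on a few compounds, and the source may have more. Where it says the series, first, only, none or still open, it means among the compounds named here.

Compound 1 `O=c1cc(/C=C/c2ccc(Cl)cc2)[nH]cc1O` and compound 3 `Cn1cc(O)c(=O)cc1/C=C/c1ccc(Cl)cc1` share a core. In a functional assay, with a stated time of 10 min (on this read-out lower numbers stand for stronger inhibition and higher numbers for weaker inhibition), compound 1 gives 11500 nM, and compound 3 gives 5720 nM. The change between them, (methyl in place of hydrogen on an aromatic nitrogen), produced a 2.0-fold lower number from compound 1 to compound 3 (0.30 log units; within the scatter). Compound 2 `COc1cc(/C=C/c2cc(=O)c(O)c[nH]2)cc(OC)c1` rests on a different core; the difference between the two cores is not broken down here. In this assay compound 2 gives 11400 nM, a number within the scatter of that of compound 1. Compound 4 `COc1cc(/C=C/c2cc(=O)c(O)cn2C)cc(OC)c1` is yet to be measured in this assay. It arises from compound 2 by methyl in place of hydrogen on an aromatic nitrogen, the same kind of change as from compound 1 to compound 3; the place is described as ortho to a large group rather than ortho to a group of 9 heavy atoms. Compound 4 is expected to show a 1.9-fold lower number from compound 2 to compound 4 (0.28 log units; within the scatter) because the earlier step gave a 2.0-fold lower number from compound 1 to compound 3 (0.30 log units; within the scatter). The estimate for compound 4 is 6000 nM, between 2500 nM and 14000 nM.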

Compound 4, half-maximal inhibitory concentration: 3740 nM
Estimate against measurement, compound 4: 1.6-fold (0.21 log units) above; the measured number falls inside the stated range.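

In this assay, methyl in place of hydrogen on an aromatic nitrogen gave a 3.0-fold lower number from compound 2 to compound 4 (0.48 log units; beyond the scatter), and this step cannot be told apart from the one on the other core: the same change on two cores in this assay, a 2.0-fold lower number (0.30 log units; within the scatter) from compound 1 to compound 3 and a 3.0-fold lower number (0.48 log units; beyond the scatter) from compound 2 to compound 4, 1.5-fold (0.18 log units) apart, within the scatter of two such steps. For the compounds shown here, both steps run in the same direction, although only the step on the core of compound 2 lies beyond the scatter. Two pairs show that the change carried over between these two cores, but they do not establish a rule for the series or explain the effect.

On these data alone, only hydrogen and methyl appear on that nitrogen, so it remains open whether an ethyl group, a longer chain or a chain ending in an amine would behave alike. Also open, as far as these compounds go, is whether the step would hold if a methoxy group replaced the hydroxy group.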